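Extending the Amide Side Chain of Compound 1 Through an Ether

The source may hold more compounds than are shown below. What is called first, only, known or untested is meant among the compounds shown, and "the series" means these compounds.

Compound 1 `CCNC(=O)C1CCN(c2nc(N)c3cc(OC)c(OC)cc3n2)CC1` is one of three closely related compounds assessed in an assay on isolated protein for displacement of a labelled ligand from Adrenergic receptor alpha-1 (Rattus norvegicus) (a lower number here means a stronger inhibitor, a higher number a weaker inhibitor), where compound 1 gives 1.64 nM. This stands second highest of the three numbers. Compound 2 `COc1cc2nc(N3CCC(C(=O)NCCO)CC3)nc(N)c2cc1OC` gives 1.73 nM, and the step of a 1.1-fold higher number from compound 1 to compound 2 (0.02 log units; within the scatter) lies within the scatter. Compound 3 `CCCCNC(=O)CCC1CCN(c2nc(N)c3cc(OC)c(OC)cc3n2)CC1` gives 0.47 nM, the lowest of the three, reached from compound 1 by the step of a 3.5-fold lower number from compound 1 to compound 3 (0.54 log units; beyond the scatter) and from compound 2 by the step of a 3.7-fold lower number from compound 2 to compound 3 (0.57 log units; beyond the scatter).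

Compound 4 `CCCCNC(=O)COC1CCN(c2nc(N)c3cc(OC)c(OC)cc3n2)CC1` has not yet been measured. It differs from compound 1 as follows: (butylcarbamoyl)methoxy in place of ethylcarbamoyl on a saturated ring carbon The entering group carries the same butylcarbamoyl end as compound 3, here attached through a methoxy link rather than an ethyl link. For the measured compounds named here, the steps that bear on this are a 3.5-fold lower number from compound 1 to compound 3 (0.54 log units; beyond the scatter) and a 3.7-fold lower number from compound 2 to compound 3 (0.57 log units; beyond the scatter), both modest, both beyond the scatter, and both towards lower numbers when a butylcarbamoyl chain replaces a shorter amide. A step of similar size in the same direction is therefore expected for compound 4, although the second hydrogen-bond acceptor in the entering group has no measured precedent among these compounds. The step expected is a 2.3-fold lower number from compound 1 to compound 4 (0.37 log units; beyond the scatter). Compound 4 is estimated at 0.7 nM, with a range from 0.3 nM to 1.8 nM.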

Compound 4, inhibition constant: 0.79 nM
Beside the measured number, compound 4's estimate is 1.1-fold (0.05 log units) below it, within the range that was stated.
By their numbers in this assay, from the lowest: compounds 3 and 4 (each within the scatter of the next); then compounds 1 and 2 (each within the scatter of the next).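

In this assay, for the compounds shown here, the saturated ring carbon three ring bonds from the ring nitrogen takes (butylcarbamoyl)methoxy with a 2.1-fold lower number from compound 1 to compound 4 (0.32 log units; beyond the scatter) and a 2.2-fold lower number from compound 2 to compound 4 (0.34 log units; beyond the scatter), so lower numbers with a butylcarbamoyl end are no longer seen only with the ethyl link of compound 3. Exchanging 2-(butylcarbamoyl)ethyl for (butylcarbamoyl)methoxy gives a 1.7-fold higher number from compound 3 to compound 4 (0.23 log units; within the scatter), so the methoxy link, with the added hydrogen-bond acceptor counted in the entering group, leaves the result indistinguishable from that of the ethyl link in this assay. Nothing measured here accounts for either the steps from the shorter amides or this match between the two links.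

The compounds shown leave open how much of the step comes from the butyl end and how much from the link, since compounds 3 and 4 each differ from compound 1 in both; (ethylcarbamoyl)methoxy would separate the two. They also leave open whether a chain longer than butyl, or a carboxylic acid or an amine in place of the butylcarbamoyl end, would keep numbers in this range.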